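Acetyl for methoxy on the anilide ring: an expected gain

The source may report more compounds than this note shows. Statements on the series, on what has been measured and on what is new or still open speak of the compounds shown alone.

Compound 1 `CCOC(=O)c1ccc(NC(=O)CSc2nnc(CNc3ccccc3)n2CC)cc1`: in an assay on isolated protein for inhibition of long-chain fatty acid transport protein 1 (Homo sapiens) (on this read-out lower numbers stand for stronger inhibition and higher numbers for weaker inhibition), compound 1 gives 330 nM
Compound 2 `CCn1c(CNc2ccccc2)nnc1SCC(=O)Nc1ccc(OC)cc1`: in this assay compound 2 gives > 1000 nM

Compound 2 stands at the weak end of the two numbers shown. Its value is a limit of this assay and not a number, as the limit of > 1000 nM in this assay, at which 1 of the 2 values shown sits, records. Among the compounds with values here, the one measured step, an at least 3.0-fold higher number from compound 1 to compound 2 (0.48 log units; beyond the scatter), is the only direct guide to how the group on the anilide ring of this core matters.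

Compound 3 `CCn1c(CNc2ccccc2)nnc1SCC(=O)Nc1ccc(C(C)=O)cc1` differs from compound 2 in one place: acetyl in place of methoxy on an aromatic carbon. Both acetyl and ethoxycarbonyl carry a carbonyl. The measured step of an at least 3.0-fold higher number from compound 1 to compound 2 (0.48 log units; beyond the scatter) is thus partly reversed by the replacement of methoxy with acetyl. On that basis, an expected drop in the number from compound 2 to compound 3 of about an at least 2.0-fold lower number from compound 2 to compound 3 (0.30 log units; that floor lies within the scatter) is estimated, in the direction of stronger inhibition, although compound 2 is only known as a limit and the size of the gain is uncertain. For compound 3 the estimate in this assay is 500 nM, expected to lie between 200 nM and 2000 nM.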

Compound 3, half-maximal inhibitory concentration: > 1000 nM
Compound 3 gave a limit, no number; the forecaster's own chance of this, stated with the estimate: 30%; at least 2.0-fold (0.30 log units) between middle value and limit.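

Carrying a carbonyl at this place on the anilide ring is not enough on its own to keep the inhibition seen with compound 1: methyl in place of ethoxy on that carbonyl carbon gives an at least 3.0-fold higher number from compound 1 to compound 3 (0.48 log units; beyond the scatter). The earlier step replaced the whole ethoxycarbonyl group and could not separate the carbonyl from the ethoxy part, whereas this step keeps the carbonyl and changes only what is attached to it, so the ethoxy part of compound 1 is tied to its measured value in this assay. The step from compound 2 to compound 3 cannot be read, and methoxy and acetyl cannot be ordered at this place, as both compounds rest on one limit of the assay and neither has a number: the limit of > 1000 nM in this assay, at which 2 of the 3 values shown sit.

Going by these compounds, how far compound 2 and compound 3 lie beyond that limit stays open, and so does whether either group retains any measurable inhibition in this assay. On these data alone, it is also open whether a carboxylic acid, a primary amide or an ester with a longer chain at this place would match, exceed or fall short of compound 1, which gives 330 nM.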